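A few compounds are considered here, and "the series" means these few. Any claim that something is new, unique, unknown or untested is made for them only; others in the source may bear on it.

Measured so far: compound 1 `CCCCCCCCC(=O)N1c2ccccc2CC1C(=O)Nc1ccc(C(F)(F)F)cc1` gives 1860 nM in a functional assay on PC-3 cells (Homo sapiens) for cytotoxicity; a higher number here means a weaker inhibitor of growth, a lower number a stronger inhibitor of growth; compound 2 `Cc1ccc(S(=O)(=O)N2c3ccccc3CC2C(=O)Nc2ccc(C(F)(F)F)cc2)cc1` gives 6680 nM.

Compound 2 stands highest of the two numbers, the step of a 3.6-fold higher number from compound 1 to compound 2 (0.56 log units; beyond the scatter) lying beyond the scatter. Compound 3 `Cc1ccc(S(=O)(=O)N2c3ccccc3CC2C(=O)Nc2cc(Cl)cc(Cl)c2)cc1` is not yet measured. It differs from compound 2 by 3,5-dichlorophenyl in place of 4-(trifluoromethyl)phenyl on an amide-type nitrogen. Among the measured compounds shown here, no measured step touches that part of the molecule; the only measured step concerns the other nitrogen, so it gives no guide here. Compound 3 is therefore expected to sit near compound 2, an estimated step of a 1.0-fold lower number from compound 2 to compound 3 (0.01 log units; within the scatter) in this assay. The estimate for compound 3 is 6500 nM, within 2200 nM to 19000 nM.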

Compound 3, concentration for 50% growth inhibition: > 10000 nM
Compound 3: no number, only a limit; the forecaster's own chance of this, stated with the estimate: 10%; middle value at least 1.5-fold (0.18 log units) away from the limit.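

In this assay compound 3 gives > 10000 nM, which is a limit of the assay and not a number. This is the first change shown on the amide-type nitrogen, and the result is an at least 1.4-fold higher number from compound 2 to compound 3 (0.17 log units; that floor lies within the scatter), so 3,5-dichlorophenyl gives no sign of stronger growth inhibition than 4-(trifluoromethyl)phenyl. The reading at this position rests on a limit: the limit of > 10000 nM in this assay, at which 1 of the 3 values shown sits.

Still open, from the compounds shown here alone, is how a phenyl ring carrying an amine or a carboxylic acid, or a plain alkyl chain, would behave on this nitrogen. Also open, going by these compounds, is whether 3,5-dichlorophenyl would fare the same alongside octylcarbonyl.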